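Iodo Substitution on a Dihydropyranone Growth Inhibitor

The source may hold more compounds than are shown below. What is called first, only, known or untested is meant among the compounds shown, and "the series" means these compounds.

Of the compounds shown here, three have been measured in a functional assay on NCI-H460 cells (Homo sapiens) for inhibition, read by sulforhodamine B assay, with a stated time of 48 h; a higher number here means a weaker inhibitor of growth, a lower number a stronger inhibitor of growth. Compound 1 `COc1cc(/C=C/C2CC(=O)C=CO2)cc(OC)c1OC` gives 127 uM, compound 2 `COc1ccc(/C=C/c2cc(=O)cco2)cc1` gives 606 uM, and compound 3 `COc1ccc(C2CC(=O)C=CO2)cc1` gives 193 uM. Compound 3 thus holds the second highest of the three numbers. Its nearest neighbour is compound 1, whose value lies within the scatter of that of compound 3, so the two cannot be told apart on these data. Compound 2 is the furthest, and its value stands beyond the scatter above that of compound 3, so compound 2 is the weaker growth inhibitor of that pair.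

Compound 4 `COc1ccc(C2CC(=O)C(I)=CO2)cc1` has not yet been measured. It differs from compound 3 by one change: iodo in place of hydrogen on a double-bonded ring carbon. Within the data shown here, no pair of measured compounds shows this change, so no step is available for comparison, and the direction must be judged from the structural change alone.

The expectation is that compound 4 will give a number not far from that of compound 3, with a 1.6-fold lower number from compound 3 to compound 4 (0.21 log units; within the scatter) expected to be small, perhaps toward a stronger inhibitor but possibly none beyond the scatter. On that basis compound 4 is estimated at 120 uM, within a range from 40 uM to 400 uM.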

Compound 4, concentration for growth inhibition (reported as GI): 74.6 uM
The estimate for compound 4 lay 1.6-fold (0.21 log units) above the measured number; the measured number falls inside the stated range.
By their numbers in this assay, from the lowest: compounds 4, 1 and 3 (each within the scatter of the next, the first and the last beyond it); then compound 2.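

In this assay, among these compounds, iodo in place of hydrogen on a double-bonded ring carbon gives a 2.6-fold lower number from compound 3 to compound 4 (0.41 log units; beyond the scatter), and this is the first step in the set between two measured compounds that differ in one place. It shows that this ring carbon, two ring bonds from the ring oxygen, can carry a substituent larger than hydrogen without loss of growth inhibition, and that compound 4 is the stronger growth inhibitor of this pair, though the step is modest. Nothing available explains the size or the direction of this step, so the result stands as an observation and gives no cause. 

The compounds shown leave open whether the gain belongs to iodo in particular or would also appear with bromo, chloro, a methyl group or a nitrile on the same carbon. They also leave open whether the same change would lower the number when made on compound 1, which carries a different group on the shared core, so this single step cannot yet be read as a general rule for the series.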